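From morpholin-4-yl to piperidin-1-yl on a carbonyl carbon

This account rests on a few compounds, and the source may have more. Where it says the series, first, only, none or still open, it means among the compounds named here.

Measurements in a functional assay on DU-145 cells (Homo sapiens) for inhibition, read by MTT assay, with a stated time of 48 h; on this read-out higher numbers stand for weaker inhibition and lower numbers for stronger inhibition:
- Compound 1 `Cn1c(/C=C2\SC(=O)N(CC(=O)Nc3cc(C(C)(C)C)on3)C2=O)nc2ccccc21`: 31400 nM
- Compound 2 `CCn1c(/C=C2\SC(=O)N(CC(=O)N3CCCCC3)C2=O)nc2ccccc21`: > 50000 nM, a limit of the assay
- Compound 3 `Cn1c(/C=C2\SC(=O)N(CC(=O)N3CCOCC3)C2=O)nc2ccccc21`: 41100 nM
- Compound 4 `Cn1c(/C=C2\SC(=O)N(CC(=O)N3CCCCC3)C2=O)nc2ccccc21`: not yet measured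

Among the measured compounds shown here, only two of the measured compounds have numbers in this assay. Compound 3 gives 41100 nM and stands within the scatter of compound 1, with a 1.3-fold higher number from compound 1 to compound 3 (0.12 log units; within the scatter). The next compound, compound 4, differs from compound 3 at one place: piperidin-1-yl in place of morpholin-4-yl on a carbonyl carbon. Piperidin-1-yl stands in place of morpholin-4-yl on a carbonyl carbon.

For the measured compounds named here, no measured step makes this exchange directly. The nearest one also changes the group on that carbonyl carbon and brings morpholin-4-yl in, and its size, a 1.3-fold higher number from compound 1 to compound 3 (0.12 log units; within the scatter), does not go beyond the scatter. Compound 2 also carries piperidin-1-yl, and its reading of > 50000 nM is a limit, not a number. A limit reading for compound 4 is therefore a real possibility because of the limit of > 50000 nM in this assay, at which 1 of the 3 values shown sits.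

No change beyond the scatter is expected, and the estimated step is a 1.1-fold higher number from compound 3 to compound 4 (0.04 log units; within the scatter). For compound 4 the expected value is 45000 nM, with an estimated range from 26000 nM to 70000 nM.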

Compound 4, half-maximal inhibitory concentration: > 50000 nM
Compound 4: only a limit was reported; the forecaster's own chance of this, stated with the estimate: 45%; middle value at least 1.1-fold (0.04 log units) away from the limit.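

In this assay compound 4 gives > 50000 nM, which is a limit of the assay and not a number. The exchange of morpholin-4-yl for piperidin-1-yl on a carbonyl carbon now has a direct reading, an at least 1.2-fold higher number from compound 3 to compound 4 (0.08 log units; that floor lies within the scatter), and the exchange of (5-(tert-butyl)-1,2-oxazol-3-yl)amino for piperidin-1-yl gives an at least 1.5-fold higher number from compound 1 to compound 4 (0.20 log units; that floor lies within the scatter), so neither floor shows a change at this position beyond the scatter. The step from compound 2 to compound 4, hydrogen in place of methyl on a saturated chain carbon bound to an aromatic nitrogen, cannot be read, and both compounds that carry piperidin-1-yl now stand at the same limit, because the reading stops there: the limit of > 50000 nM in this assay, at which 2 of the 4 values shown sit.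

Going by these compounds, how far the true value of compound 4 lies from that limit remains open, and with it whether the exchange from morpholin-4-yl to piperidin-1-yl amounts to a step beyond the scatter. Also open, on these data alone, is what a piperazin-1-yl ring or an open-chain amine such as dimethylamino would give on the same carbonyl carbon of the shared core.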